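This account rests on a few compounds, and the source may have more. Where it says the series, first, only, none or still open, it means among the compounds named here.

Working notes on a small dichloroacetamide series run in a functional assay on NCI-H460 cells (Homo sapiens) for cytotoxicity, read by MTT assay, with a stated time of 68 h; on this read-out lower numbers stand for stronger inhibition and higher numbers for weaker inhibition. Compound 1 `O=C(Nc1cccc(-c2ccc(F)cc2)c1)C(Cl)Cl` returns only a limit in this assay, > 50000 nM, not a number; this is the limit of > 50000 nM in this assay, at which 1 of the 3 values shown sits. Compound 2 `COc1ccccc1-c1cc(NC(=O)C(Cl)Cl)cc(-c2ccccc2OC)c1` also returns a limit, > 30000 nM, which is the limit of > 30000 nM in this assay, at which 1 of the 3 values shown sits. Among the measured compounds shown here, compound 3 `COc1ccc(-c2cc(NC(=O)C(Cl)Cl)cc(-c3ccc(OC)c(F)c3)c2)cc1F` is the sole compound with a measured number, giving 1760 nM in this assay. For the measured compounds named here, no two measured compounds differ in a single place, so no measured step size exists in this set. Compound 4 `O=C(Nc1cccc(-c2ccc(C(F)(F)F)cc2)c1)C(Cl)Cl` differs from compound 1 by trifluoromethyl in place of fluoro on an aromatic carbon. Nothing measured here ties this change to a gain in potency. The expected step is a number no higher from compound 1 to compound 4 (the limit leaves the size open), none beyond the scatter. Compound 4 is estimated at 50000 nM, within a range of 15000 nM to 150000 nM, and is expected most likely to be reported again only as a limit.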

Compound 4, half-maximal inhibitory concentration: 33600 nM
Estimate against measurement, compound 4: 1.5-fold (0.17 log units) above, within the range that was stated.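

Among the compounds shown here, on an aromatic carbon para to a large group, trifluoromethyl in place of fluoro gives the first readable step in this assay: an at least 1.4-fold lower number from compound 1 to compound 4 (0.17 log units; that floor lies within the scatter). Compound 4 gives a measured number, so this change now has a value on one side, but no gain in potency can be claimed from it. The true size of the step stays open because compound 1 is only a limit: the limit of > 50000 nM in this assay, at which 1 of the 4 values shown sits.

On these data alone, how an amine or a carboxylic acid at this position would read in this assay remains open.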